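Azetidine oxadiazoles: aryl amide in place of cyclohexyl amide

The compounds below may be only part of what the source reports. "The series", "measured", "known", "first", "only" and "open" are said of these compounds alone.

Compound 1 `O=C(C1CCCCC1)N1CC(c2nc(-c3cccc(F)c3)no2)C1` — > 10000 nM
Compound 2 `Cc1ccc(S(=O)(=O)N2CC(c3nc(-c4cccc(Cl)c4)no3)C2)cc1` — 920 nM

Of the compounds shown here, two have been measured in an assay on HEK293 cells for negative allosteric modulation of metabotropic glutamate receptor 5 (Homo sapiens), read by FLIPR; on this read-out lower numbers stand for stronger inhibition and higher numbers for weaker inhibition. For compound 1 the read-out is a limit of the assay rather than a number, at > 10000 nM. This is the limit described in the limit of > 10000 nM in this assay, at which 1 of the 2 values shown sits. Compound 2, the sulfonamide of the shared core, gives 920 nM in this assay. Going by the values given here, no step between compounds differing in one place has been measured, so nothing is known about how much a single change moves the read-out here.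

Compound 3 `O=C(c1ccc(F)c(F)c1)N1CC(c2nc(-c3cccc(F)c3)no2)C1` has not yet been measured. It differs from compound 1 in one place: 3,4-difluorophenyl in place of cyclohexyl on a carbonyl carbon. Since compound 1 sits at a limit, the step to compound 3 cannot be computed; only an expectation can be given. The aromatic amide of compound 3 is expected to move the read-out beyond the scatter in the direction of stronger inhibition, by an at least 6.6-fold lower number from compound 1 to compound 3 (0.82 log units; beyond the scatter). Compound 3 is accordingly estimated to give 1500 nM in this assay, within a range from 300 nM to 10000 nM, with a real chance that only a limit is again reported.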

Compound 3, half-maximal inhibitory concentration: > 10000 nM
Compound 3 ended at the assay's limit; the forecaster's own chance of this, stated with the estimate: 25%; at least 6.6-fold (0.82 log units) between middle value and limit.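

In this assay compound 3 gives > 10000 nM as a limit of the assay, not a number. Going by these compounds alone, no step from compound 1 to compound 3 can be read, because both compounds stand at a limit: the limit of > 10000 nM in this assay, at which 2 of the 3 values shown sit. The compounds shown leave open whether 3,4-difluorophenyl or cyclohexyl on a carbonyl carbon goes with stronger inhibition.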